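From 4-chlorophenyl to phenyl in compound 3

A few compounds are considered here, and "the series" means these few. Any claim that something is new, unique, unknown or untested is made for them only; others in the source may bear on it.

Measured in a functional assay on A549 cells (Homo sapiens) for antiproliferative activity, read by MTT assay, with a stated time of 48 h; a higher number here means a weaker inhibitor, a lower number a stronger inhibitor:
Compound 1 `COc1ccc(C(=O)Nc2nnc(/C=C/c3cc(OC)c(OC)c(OC)c3Br)s2)cc1` gives 150 nM
Compound 2 `COc1cc(/C=C/c2nnc(NC(=O)c3cccc(Cl)c3)s2)c(Br)c(OC)c1OC` gives 70 nM
Compound 3 `COc1cc(/C=C/c2nnc(NC(=O)c3ccc(Cl)cc3)s2)c(Br)c(OC)c1OC` gives 140 nM

In this assay the number for compound 3 stands within the scatter of both other compounds. Only one gap among the three goes beyond the scatter, and modestly: a 2.1-fold lower number from compound 1 to compound 2 (0.33 log units; beyond the scatter) in this set.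

Compound 4 `COc1cc(/C=C/c2nnc(NC(=O)c3ccccc3)s2)c(Br)c(OC)c1OC` differs from compound 3 by hydrogen in place of chloro on an aromatic carbon in the change of 4-chlorophenyl to phenyl, which is hydrogen in place of chloro on an aromatic carbon, para to a large group. Among the compounds with values here, no measured compound carries plain phenyl at this place, so the data offer no direct precedent.

The nearest evidence is indirect. Chloro in place of methoxy gave a 1.1-fold lower number from compound 1 to compound 3 (0.03 log units; within the scatter) and 4-chlorophenyl in place of 3-chlorophenyl gave a 2.0-fold higher number from compound 2 to compound 3 (0.30 log units; within the scatter) in the same test. Both changes at this ring stayed within the scatter, and the largest gap, in compound 2 against compound 1, remained modest. In this assay no step beyond the scatter is therefore expected, in either direction. The estimated change is a 1.2-fold lower number from compound 3 to compound 4 (0.07 log units; within the scatter) and is expected to stay within the scatter. Compound 4 is expected at 120 nM with an estimated range from 50 nM to 290 nM as its likely span.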

Compound 4, half-maximal inhibitory concentration: 110 nM
For compound 4 the middle estimate is 1.1-fold (0.04 log units) above the measured one; measured number inside the range.
By their numbers in this assay, from the lowest: compounds 2, 4, 3 and 1 (each within the scatter of the next, the first and the last beyond it).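

In this assay, hydrogen in place of chloro on this aromatic carbon gives a 1.3-fold lower number from compound 3 to compound 4 (0.10 log units; within the scatter), so the benzoyl compound shows that this place need not carry any substituent for the number to stay within the scatter of the 4-chlorophenyl compound. The same holds for the two other amides, with a 1.6-fold higher number from compound 2 to compound 4 (0.20 log units; within the scatter) and a 1.4-fold lower number from compound 1 to compound 4 (0.13 log units; within the scatter), so plain phenyl lies within the scatter of both the 3-chlorophenyl and the 4-methoxyphenyl compounds, even though those two are themselves separated by a 2.1-fold lower number from compound 1 to compound 2 (0.33 log units; beyond the scatter). No accompanying measurement on these compounds offers an explanation for these numbers.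

The compounds shown leave open whether an amine, a carboxylic acid or a longer chain such as butoxy on this ring would move the number beyond the scatter, as chloro, methoxy and hydrogen have so far covered only a narrow span of groups. They also leave open whether the same result at this ring would hold if the bromo or the methoxy groups elsewhere on the shared core were exchanged.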